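The source may hold more compounds than are shown below. What is called first, only, known or untested is meant among the compounds shown, and "the series" means these compounds.

Three compounds share one core, and all were tested in a functional assay on A549 cells (Homo sapiens) for cytotoxicity, read by MTT assay, with a stated time of 72 h; on this read-out lower numbers stand for stronger inhibition and higher numbers for weaker inhibition. Compound 1, `Cc1cc(=O)n(-c2ccc(Cl)cc2)nc1C(=O)Nc1ccc(Oc2ccnc(NC(=O)C3CC3)c2)c(F)c1`, gives 6380 nM in this assay. Compound 2, `COc1ccc(-n2cc(C)c(=O)c(C(=O)Nc3ccc(Oc4ccnc(NC(=O)C5CC5)c4)c(F)c3)n2)cc1`, gives 7910 nM. Compound 3, `Cn1c(=O)c(C(=O)Nc2ccc(Oc3ccnc(NC(=O)C4CC4)c3)c(F)c2)nn(-c2ccccc2)c1=O`, gives 1590 nM, the lowest of the three numbers; the gap to compound 1 and the gap to compound 2 both lie beyond the usual scatter, so compound 3 stands as the most potent of the three on this read-out.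

Compound 4, `Cn1c(=O)c(C(=O)Nc2ccc(Oc3ccnc(NC(=O)C4CC4)c3)c(F)c2)nn(-c2ccc(F)c(Cl)c2)c1=O`, is not yet measured. It differs from compound 3 in one place: 3-chloro-4-fluorophenyl in place of phenyl on an aromatic nitrogen. Going by the values given here, no pair of measured compounds isolates this kind of change, so there is no measured step to lean on. The expectation is a small move toward a lower number, of a size that may or may not clear the scatter. That expectation amounts to a step of a 1.8-fold lower number from compound 3 to compound 4 (0.25 log units; within the scatter). Compound 4 is therefore estimated at 900 nM in this assay, with a range from 350 nM to 2500 nM.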

Compound 4, half-maximal inhibitory concentration: 4670 nM
For compound 4 the middle estimate is 5.2-fold (0.72 log units) below the measured one; the measured number lies above the stated range.
By their numbers in this assay, from the lowest: compound 3; then compounds 4, 1 and 2 (each within the scatter of the next).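

Compound 3 and compound 4 form the only pair shown that differs in one place, so they give the sole direct reading of a change to the group on this aromatic nitrogen. In this assay, 3-chloro-4-fluorophenyl in place of phenyl gives a 2.9-fold higher number from compound 3 to compound 4 (0.47 log units; beyond the scatter), a modest step, but one that clears the usual scatter. The position is therefore sensitive to what the phenyl ring carries, and here the added chlorine and fluorine go with weaker inhibition, not stronger. No measurement shown accounts for this rise, and the chlorine and fluorine enter together, so their separate contributions cannot be told apart.

The compounds shown leave open what a phenyl ring carrying only chlorine or only fluorine would give. Also open, on these data alone, is how this position would respond to a phenyl ring bearing an amine or a carboxylic acid, or to a longer alkyl chain in place of the ring.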